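A few compounds are considered here, and "the series" means these few. Any claim that something is new, unique, unknown or untested is made for them only; others in the source may bear on it.

Working notes on the series. Compound 2 `CCOc1ccc(NC(=O)c2cccc(/C=C3\CC(=O)N(c4ccccc4)C3=O)c2)cc1` gives 91500 nM in an ADME assay on SW480 cells (Homo sapiens) for cytotoxicity, read by MTT assay, with a stated time of 72 h (on this read-out lower numbers stand for stronger inhibition and higher numbers for weaker inhibition), the lowest of the two numbers shown; compound 1 `Cc1ccc(N2C(=O)C/C(=C\c3cccc(C(=O)Nc4cccc(F)c4)c3)C2=O)cc1` gives 96900 nM, within the scatter of compound 2. Compound 3 `COc1ccc(NC(=O)c2cccc(/C=C3\CC(=O)N(c4ccccc4)C3=O)c2)cc1` reaches only a limit, > 100000 nM, and not a number. Within the data shown here, the one measured step, an at least 1.0-fold higher number from compound 2 to compound 3 (0.03 log units; that floor lies within the scatter), stays within the scatter, and the limit it runs into is the limit of > 100000 nM in this assay, at which 1 of the 3 values shown sits. Compound 4 `CCc1cccc(NC(=O)c2cccc(/C=C3\CC(=O)N(c4ccccc4)C3=O)c2)c1` differs from compound 2 by 3-ethylphenyl in place of 4-ethoxyphenyl on an amide-type nitrogen. Among the measured compounds shown here, no measured step changes the group on the amide-type nitrogen in this way, so the step from compound 2 to compound 4 is expected to stay close to the scatter, with the same risk of reaching the limit that compound 3 shows. Compound 4 is estimated at 95000 nM, within 50000 nM to 200000 nM, an expected step of a 1.0-fold higher number from compound 2 to compound 4 (0.02 log units; within the scatter).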

Compound 4, half-maximal inhibitory concentration: 88600 nM
Beside the measured number, compound 4's estimate is 1.1-fold (0.03 log units) above it; the range from low to high includes it.
By their numbers in this assay, from the lowest: compounds 4, 2 and 1 (each within the scatter of the next). At a limit, above all of these: compound 3.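

Putting 3-ethylphenyl in place of 4-ethoxyphenyl on an amide-type nitrogen in this assay gives a 1.0-fold lower number from compound 2 to compound 4 (0.01 log units; within the scatter), so a change of the whole group at this position, including loss of the hydrogen-bond acceptor counted for 4-ethoxyphenyl, stays within the scatter. The other new step, an at least 1.1-fold lower number from compound 3 to compound 4 (0.05 log units; that floor lies within the scatter), can be read only as a floor, because compound 3 stands at a limit and not at a number: the limit of > 100000 nM in this assay, at which 1 of the 4 values shown sits.

Open, from the compounds shown here alone, is whether an aminophenyl or a carboxyphenyl group on the amide-type nitrogen would move the number beyond the scatter.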